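Swapping Chloro for Amino on an Inactive Urea Scaffold

A few compounds are considered here, and "the series" means these few. Any claim that something is new, unique, unknown or untested is made for them only; others in the source may bear on it.

Compound 1 `Nc1nn(C(=O)Nc2ccc(Cc3ccccc3)cc2)c2ccccc12` gives in a functional assay on NCI-H322M cells (Homo sapiens) for antiproliferative activity, read by sulforhodamine B assay, with a stated time of 48 h (a lower number here means a stronger inhibitor of growth, a higher number a weaker inhibitor of growth), the value > 100000 nM, which is a limit of the assay rather than a number.
Compound 2 `Nc1nn(C(=O)Nc2ccc(Cc3ccccc3)cc2)c2ccc(Cl)cc12` gives in this assay the value > 100000 nM, again only a limit.

Compound 2 thus stands at the limit, where both measured values sit (the limit of > 100000 nM in this assay, at which 2 of the 2 values shown sit). Going by the values given here, the single measured step, a step that the two limits leave unreadable from compound 1 to compound 2, cannot be read in size. Compound 3 `Nc1ccc2c(c1)c(N)nn2C(=O)Nc1ccc(Cc2ccccc2)cc1` differs from compound 2 by amino in place of chloro on an aromatic carbon. Among the compounds with values here, no measured step bears on this change, so no direction can be drawn, and a limit in this assay is the most probable result. Compound 3 is estimated at 150000 nM (range 30000 nM to 1000000 nM). The expected step is a step that the limit leaves unreadable from compound 2 to compound 3.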

Compound 3, concentration for total growth inhibition: 27500 nM
For compound 3 the middle estimate is 5.5-fold (0.74 log units) above the measured one; measured number below the stated range.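

This position can respond after all: with amino on this aromatic carbon, the change gives an at least 3.6-fold lower number from compound 2 to compound 3 (0.56 log units; beyond the scatter), and set against the unsubstituted compound it gives an at least 3.6-fold lower number from compound 1 to compound 3 (0.56 log units; beyond the scatter). Only compound 3 has a readable number in this assay, and the other two remain at a limit of the assay: the limit of > 100000 nM in this assay, at which 2 of the 3 values shown sit.

These values do not show why amino has this effect, and the true size of both steps stays unknown. From the compounds shown here alone, whether a methylamino, hydroxyl or acetamido group on the same carbon would do better or worse remains open.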